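The source may report more compounds than this note shows. Statements on the series, on what has been measured and on what is new or still open speak of the compounds shown alone.

Compound 1 `OCC#CCSc1cnc2ccccc2c1[Se]CC#CCBr` and compound 2 `C#CCSc1cnc2ccccc2c1[Se]CC#CCBr` share one core. In a functional assay on CCRF-CEM cells (Homo sapiens) for cytotoxicity, read by sulforhodamine B assay, with a stated time of 72 h (on this read-out lower numbers stand for stronger inhibition and higher numbers for weaker inhibition), compound 1 gives 0.2 ug/mL, and compound 2 gives 0.3 ug/mL. Compound 2 thus carries the higher of the two numbers, though a 1.5-fold higher number from compound 1 to compound 2 (0.18 log units; within the scatter) stays inside the scatter. Compound 3 `C#CCSc1cnc2ccccc2c1SCC#CCO` differs from compound 2 by a group of 6 heavy atoms (4 carbon, 1 oxygen, 1 sulfur; no ring) in place of a group of 6 heavy atoms (4 carbon, 1 selenium, 1 bromine; no ring), on an aromatic carbon. For the measured compounds named here, no measured step touches that position, so the only guidance is indirect: the small step from compound 1 to compound 2 suggests that adding or removing a terminal hydroxymethyl on a triple-bonded carbon changes little. Compound 3 is therefore estimated at 0.5 ug/mL, within 0.15 ug/mL to 1.5 ug/mL, a step of a 1.7-fold higher number from compound 2 to compound 3 (0.22 log units; within the scatter) that is expected to stay within the scatter.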

Compound 3, concentration for 50% inhibition: 3.2 ug/mL
Compound 3: the middle estimate sits 6.4-fold (0.81 log units) below what was measured; measured number above the stated range.
By their numbers in this assay, from the lowest: compounds 1 and 2 (each within the scatter of the next); then compound 3.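

At this aromatic carbon, opposite the ring nitrogen, the group matters far more than the earlier hydroxymethyl change suggested: in this assay, replacing the group holding selenium and bromine with the one holding sulfur and oxygen gives an 11-fold higher number from compound 2 to compound 3 (1.03 log units; beyond the scatter). Nothing available explains this loss of cytotoxic strength.

Selenium, bromine, sulfur and oxygen all change in this one step, so the compounds shown cannot say which atom counts. From the compounds shown here alone, how an amine or a longer chain at this carbon would read also stays open.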